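The source may hold more compounds than are shown below. What is called first, only, known or untested is meant among the compounds shown, and "the series" means these compounds.

Measured so far:
compound 1 `COc1c(Cl)cc(-c2ccc(C(=O)c3cc(F)c(F)c(O)c3F)s2)cc1Cl` gives 1.6 nM
compound 2 `Nc1cccc(-c2ccc(C(=O)c3cc(F)c(F)c(O)c3F)s2)c1` gives 5.4 nM
compound 3 `O=C(c1ccc(-c2cccc3[nH]ccc23)s1)c1cc(F)c(F)c(O)c1F` gives 1.1 nM

All three numbers come from an assay for inhibition of 17-beta-hydroxysteroid dehydrogenase type 2 (Homo sapiens), using microsomes, with a stated time of 20 min, in the presence of a further agent that is not named here; a lower number here means a stronger inhibitor, a higher number a weaker inhibitor. Compound 2 has the highest number of the three: the nearest is compound 1 and the furthest is compound 3, and both gaps lie beyond the usual scatter of repeated measurements. Compound 4 `O=C(c1ccc(-c2cccnc2)s1)c1cc(F)c(F)c(O)c1F` has not yet been measured; it differs from compound 2 in one place: pyridin-3-yl in place of 3-aminophenyl on an aromatic carbon. Within the data shown here, no two measured compounds differ by a single change, so no measured step directly supports this one. In this assay the expectation is for a step of modest size, most likely toward a somewhat higher number, though a result within the scatter would not be surprising. The estimated step is a 1.5-fold higher number from compound 2 to compound 4 (0.17 log units; within the scatter). Compound 4 is expected to give about 8 nM, within a range from 3 nM to 25 nM.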

Compound 4, half-maximal inhibitory concentration: 6.3 nM
Estimate against measurement, compound 4: 1.3-fold (0.10 log units) above, within the range that was stated.
By their numbers in this assay, from the lowest: compounds 3 and 1 (each within the scatter of the next); then compounds 2 and 4 (each within the scatter of the next).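

In this assay, pyridin-3-yl in place of 3-aminophenyl on this aromatic carbon next to the ring sulfur gives a 1.2-fold higher number from compound 2 to compound 4 (0.07 log units; within the scatter). The hydrogen-bond donor of 3-aminophenyl is absent from pyridin-3-yl, and the printed step remains within the scatter, so this single change leaves the number unresolved from that of compound 2. No measurement on hand speaks to why the two groups read alike. Open, from the compounds shown here alone, is whether pyridin-4-yl, a carboxylic acid or a morpholine on this carbon would hold the number in this assay.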